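The source may hold more compounds than are shown below. What is called first, only, known or untested is meant among the compounds shown, and "the series" means these compounds.

For the measured compounds named here, in an ADME assay (liver) for metabolic stability, with Liver microsome (Homo sapiens) as the target, using microsomes and NADPH, with a stated time of 30 min, tested at 1 uM (on this read-out higher numbers stand for fast clearance and lower numbers for slow clearance), compound 3 `CCn1cc(-c2cc(C(O)(C(F)(F)F)C(F)(F)F)cnc2N2CCN(S(=O)(=O)c3ccc(N)nc3)CC2)cn1` gives 20 mL.min-1.g-1, the only actual number in this small set. Compound 1 `Nc1ccc(S(=O)(=O)N2CCN(c3ncc(C(O)(C(F)(F)F)C(F)(F)F)cc3C#CC3CC3)CC2)cn1` reports only a limit, < 14 mL.min-1.g-1. Compound 2 `Nc1ccc(S(=O)(=O)N2CCN(c3ncc(C(O)(C(F)(F)F)C(F)(F)F)cc3C#CCCO)CC2)cn1` also reports only a limit, < 14 mL.min-1.g-1. The step between those two, a step that the two limits leave unreadable from compound 1 to compound 2, therefore gives no usable size.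

Compound 4 `CC(C)(C)n1cc(-c2cc(C(O)(C(F)(F)F)C(F)(F)F)cnc2N2CCN(S(=O)(=O)c3ccc(N)nc3)CC2)cn1` carries tert-butyl in place of ethyl on an aromatic nitrogen. The nearest measured steps are an at least 1.4-fold higher number from compound 1 to compound 3 (0.15 log units; that floor lies within the scatter) and an at least 1.4-fold higher number from compound 2 to compound 3 (0.15 log units; that floor lies within the scatter). Both install the 1-ethyl-1H-pyrazol-4-yl group, replacing 2-cyclopropylethynyl in the first case and 4-hydroxybut-1-yn-1-yl in the second. Going by the values given here, neither varies the group on the aromatic nitrogen, so they bear on this change only indirectly, and no measured step sets its size or direction.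

In this assay, no step beyond the scatter is therefore expected, and the range is kept wide. The expected step is a 1.2-fold higher number from compound 3 to compound 4 (0.08 log units; within the scatter). For compound 4 the estimated value is 24 mL.min-1.g-1, with an expected range of 13 mL.min-1.g-1 to 48 mL.min-1.g-1.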

Compound 4, intrinsic clearance in microsomes: 86 mL.min-1.g-1
Beside the measured number, compound 4's estimate is 3.6-fold (0.55 log units) below it; the measured number lies above the stated range.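

For the compounds shown here, the group on the aromatic nitrogen is not a neutral position in this assay: tert-butyl in place of ethyl gives a 4.3-fold higher number from compound 3 to compound 4 (0.63 log units; beyond the scatter), the first step in this set with a number at both ends. Against the compounds carrying the triple bond, the 1-(tert-butyl)-1H-pyrazol-4-yl group gives an at least 6.1-fold higher number from compound 2 to compound 4 (0.78 log units; beyond the scatter) and an at least 6.1-fold higher number from compound 1 to compound 4 (0.78 log units; beyond the scatter), whereas the floors for the 1-ethyl-1H-pyrazol-4-yl group lay within the scatter. Both of these new steps are floors and not sizes, as each starts from a limit: the limit of < 14 mL.min-1.g-1 in this assay, at which 2 of the 4 values shown sit.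

As far as these compounds go, with only ethyl and tert-butyl on this nitrogen, it remains open whether the step follows the carbon count or belongs to tert-butyl alone. An isopropyl group there, or a chain ending in a hydroxyl or an amine, would test this.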